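A few compounds are considered here, and "the series" means these few. Any claim that something is new, unique, unknown or untested is made for them only; others in the source may bear on it.

Measured so far:

Compound 1 `CC[C@@H]1C(=O)N(C)c2cnc(-n3ccc4cc(C(=O)NCC(C)C)ccc43)nc2N1C1CCCC1`: 638 nM
Compound 2 `CCC1C(=O)N(C)c2cnc(-n3ccc4cc(C(=O)NCC(C)C)ccc43)nc2N1c1ccn(C)n1`: 5600 nM
Compound 3 `CC[C@@H]1C(=O)N(C)c2cnc(-n3ccc4cc(C(=O)NC5CCCC5)ccc43)nc2N1C1CCCC1`: 414 nM

All three were tested in a functional assay on K562 cells (Homo sapiens) for antiproliferative activity, read by CCK-8 assay, with a stated time of 72 h; on this read-out lower numbers stand for stronger inhibition of growth and higher numbers for weaker inhibition of growth. Compound 3 differs from compound 1 by cyclopentyl in place of isobutyl on an amide-type nitrogen, and that change gave a 1.5-fold lower number from compound 1 to compound 3 (0.19 log units; within the scatter). Compound 2 is built on a different core from compound 1; the difference between the two cores is not broken down here, and the values of compound 2 and compound 1 show compound 2 with a clearly higher number in this assay. Compound 4 `CCC1C(=O)N(C)c2cnc(-n3ccc4cc(C(=O)NC5CCCC5)ccc43)nc2N1c1ccn(C)n1` has not been measured yet. For the measured compounds named here, it differs from compound 2 by cyclopentyl in place of isobutyl on an amide-type nitrogen, the same change, at the same place, as the one from compound 1 to compound 3. The step from compound 2 to compound 4 is therefore expected to be small, about a 1.4-fold lower number from compound 2 to compound 4 (0.15 log units; within the scatter), because the matching step measured a 1.5-fold lower number from compound 1 to compound 3 (0.19 log units; within the scatter). Compound 4 is estimated at 4000 nM, expected to fall between 1500 nM and 10000 nM.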

Compound 4, concentration for 50% growth inhibition: 31300 nM
The estimate for compound 4 lay 7.8-fold (0.89 log units) below the measured number; the whole stated range lies below it.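

Putting cyclopentyl in place of isobutyl on the amide-type nitrogen gave a 5.6-fold higher number from compound 2 to compound 4 (0.75 log units; beyond the scatter) in this assay. The step measured on one core therefore did not predict the step on the other, and this change does not carry over between these two cores: the same change on two cores in this assay, a 1.5-fold lower number (0.19 log units; within the scatter) from compound 1 to compound 3 and a 5.6-fold higher number (0.75 log units; beyond the scatter) from compound 2 to compound 4, 8.6-fold (0.94 log units) apart, beyond the scatter of two such steps

This shows only that the outcome of the change differed between two cores in one assay; it does not show which part of the cores accounts for the difference, or how the change would behave across the wider series.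

From the compounds shown here alone, it remains open how the same change would behave on further cores. Also open, going by these compounds, is what a longer chain or a chain ending in an amine on that nitrogen would do on each core.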